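Cyano for Trifluoromethyl: Cytotoxicity Appears Unchanged

A few compounds are considered here, and "the series" means these few. Any claim that something is new, unique, unknown or untested is made for them only; others in the source may bear on it.

All three measured compounds were tested in an ADME assay on HepG2 cells (Homo sapiens) for cytotoxicity, read by CellTiter-Glo, with a stated time of 72 h; on this read-out lower numbers stand for an effect already at smaller amounts and higher numbers for an effect only at larger amounts of compound:

compound 1 `C/C1=C/C2=C[C@H](C)C[C@@]23O[C@]2(CC(C)(C)C[C@@H]2[C@@]1(O)C(F)(F)F)[C@@H](C)C3=O` gives 26000 nM.
compound 2 `CC1=C2CC(C)(C)/C=C/C(=O)/C(C)=C\C3=C[C@H](C)C[C@]3(O2)[C@@]1(O)C(F)(F)F` gives 26000 nM.
compound 3 `CC1=C2CC(C)(C)/C=C/C(=O)/C(C)=C\C3=C[C@H](C)C[C@]3(O2)[C@@]1(O)C#N` gives 26000 nM.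

Among the compounds with values here, the three values sit at the same digits, so no compound can be called more or less toxic than another on this read-out. Compounds 2 and 3 share a core and differ in one place: cyano in place of trifluoromethyl on a saturated ring carbon. That exchange made no change at the digits printed from compound 2 to compound 3 (within the scatter). Compound 1 is built on a different core; the difference between the two cores is not broken down here, and its value is level with compounds 2 and 3.

Compound 4 `C/C1=C/C2=C[C@H](C)C[C@@]23O[C@]2(CC(C)(C)C[C@@H]2[C@@]1(O)C#N)[C@@H](C)C3=O` has not yet been measured. It relates to compound 1 as compound 3 relates to compound 2: cyano in place of trifluoromethyl on a saturated ring carbon. The surroundings are not identical, since in compound 2 the saturated ring carbon belongs to a five-membered non-aromatic ring with one oxygen in a fused or bridged system of three rings, while in compound 1 it belongs to an eight-membered non-aromatic ring with one oxygen in a system of four rings. It is therefore the same kind of change, not the same change.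

Because no change at the digits printed from compound 2 to compound 3 (within the scatter) was seen on the other core, the step from compound 1 to compound 4 is expected to be no change at the digits printed from compound 1 to compound 4 (within the scatter). Compound 4 is thus estimated at 26000 nM in this assay , between 13000 nM and 52000 nM.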

Compound 4, half-maximal effective concentration: 26000 nM
The estimate for compound 4 equals the measured number at the digits printed; low and high end bracket the measured number.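

In this assay, cyano in place of trifluoromethyl on a saturated ring carbon of the core of compound 1 gives no change at the digits printed from compound 1 to compound 4 (within the scatter). Set beside the same exchange on the other core, the two steps agree: the same change on two cores in this assay, no change at the digits printed (within the scatter) from compound 2 to compound 3 and no change at the digits printed (within the scatter) from compound 1 to compound 4, 1.0-fold (0.00 log units) apart, within the scatter of two such steps. As far as these compounds go, this shows that, on these two cores and on this one read-out, the exchange behaved alike, but it does not show that it would do so on a third core or in any other kind of measurement, and as neither pair shows a step beyond the scatter, whether a real shift in the value would also carry from one core to the other remains untested.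

The compounds shown leave open whether a different group on this saturated ring carbon, such as an amine, a carboxylic acid or a longer chain, would stay level with these four compounds in this assay. Within the data shown here, they also leave open whether any single exchange at this place can move the value at all, since trifluoromethyl and cyano are the only two groups seen there.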